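Furan to fluoromethoxyphenyl swap: cytotoxicity outlook for compound 4

A few compounds are considered here, and "the series" means these few. Any claim that something is new, unique, unknown or untested is made for them only; others in the source may bear on it.

Compound 1 `Fc1ccc(-c2ccc3c(NCCCNCc4ccco4)ccnc3c2)cc1` gives 7760 nM in an ADME assay on HepG2 cells (Homo sapiens) for cytotoxicity, read by luminescence, CellTiter-Glo and ATP content, with a stated time of 72 h; on this read-out higher numbers stand for an effect only at larger amounts of compound and lower numbers for an effect already at smaller amounts. Compound 2 `COc1ccc(F)cc1CNCCCNc1ccnc2cc(-c3ccc(F)cc3)ccc12` differs from it by 5-fluoro-2-methoxyphenyl in place of furan-2-yl on a saturated chain carbon bound to an amine nitrogen and gives 770 nM in this assay; the step is a 10-fold lower number from compound 1 to compound 2 (1.00 log units; beyond the scatter). Compound 3 `COc1ccc(-c2ccc3c(NCCCNCc4ccco4)ccnc3c2)cc1` has a core that differs from the core of compound 1 by methoxy in place of fluoro on an aromatic carbon; in this assay compound 3 gives 6000 nM, and the step is a 1.3-fold lower number from compound 1 to compound 3 (0.11 log units; within the scatter). Compound 4 `COc1ccc(-c2ccc3c(NCCCNCc4cc(F)ccc4OC)ccnc3c2)cc1` is not yet measured. It differs from compound 3 by 5-fluoro-2-methoxyphenyl in place of furan-2-yl on a saturated chain carbon bound to an amine nitrogen, the same change at the same place as between compound 1 and compound 2. For compound 4 a step of a 10-fold lower number from compound 3 to compound 4 (1.00 log units; beyond the scatter) in this assay is expected, because a 10-fold lower number from compound 1 to compound 2 (1.00 log units; beyond the scatter) was seen for this change on a core whose only difference is the one counted above. Compound 4 is therefore estimated at 600 nM, with a likely range from 250 nM to 1500 nM.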

Compound 4, half-maximal effective concentration in the HepG2 assay: 5960 nM
Compound 4: the middle estimate sits 9.9-fold (1.00 log units) below what was measured; the whole stated range lies below it.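

In the HepG2 assay compound 3 gives 6000 nM and compound 4 gives 5960 nM; the change from furan-2-yl to 5-fluoro-2-methoxyphenyl gives a 1.0-fold lower number from compound 3 to compound 4 (0.00 log units; within the scatter), so the step seen on the core of compound 1 does not carry over to the core of compound 3: the same change on two cores in the HepG2 assay, a 10-fold lower number (1.00 log units; beyond the scatter) from compound 1 to compound 2 and a 1.0-fold lower number (0.00 log units; within the scatter) from compound 3 to compound 4, 10-fold (1.00 log units) apart, beyond the scatter of two such steps

Read the other way, methoxy in place of fluoro on an aromatic carbon gives a 7.7-fold higher number from compound 2 to compound 4 (0.89 log units; beyond the scatter), so the two changes do not add up independently in these four compounds: the same change on two cores in the HepG2 assay, a 1.3-fold lower number (0.11 log units; within the scatter) from compound 1 to compound 3 and a 7.7-fold higher number (0.89 log units; beyond the scatter) from compound 2 to compound 4, 10-fold (1.00 log units) apart, beyond the scatter of two such steps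

This rests on a single pair of cores and shows neither why the step differs nor which core is the more typical. In a physicochemical assay for acid dissociation, compound 3 gives 9.47 and compound 4 gives 9.47.

From the compounds shown here alone, it remains open whether a core with chloro or methyl in place of methoxy on an aromatic carbon follows compound 2 or compound 4. The same question stands for a longer chain.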